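Fluoro in Place of Methoxy on a Weak Sulfanyl Analogue

The source may report more compounds than this note shows. Statements on the series, on what has been measured and on what is new or still open speak of the compounds shown alone.

Two compounds built on one shared core have been examined in a functional assay on COLO 205 cells (Homo sapiens) for inhibition, read by sulforhodamine B assay, with a stated time of 48 h; a lower number here means that less compound is tolerated, a higher number that more compound is tolerated. Compound 1 `COc1ccc(CNc2nc3cc(N)cc(N)c3nc2-c2ccccc2)cc1` gives 74100 nM in this assay. Compound 2 `COc1ccc(Sc2nc3cc(N)cc(N)c3nc2-c2ccccc2)cc1` returns only a limit in this assay, < 100000 nM, which is not a number. Its place among the values shown is therefore known no further than the limit of < 100000 nM in this assay, at which 1 of the 2 values shown sits. Compound 3 `Nc1cc(N)c2nc(-c3ccccc3)c(Sc3ccc(F)cc3)nc2c1` has not yet been measured; it differs from compound 2 by fluoro in place of methoxy on an aromatic carbon. Within the data shown here, no step between measured compounds is available to show how large such a change runs, and the starting point in compound 2 is itself only a limit. The step from compound 2 to compound 3 is accordingly expected to stay within the usual scatter, estimated as a step that the limit leaves unreadable from compound 2 to compound 3. Compound 3 is expected to give about 70000 nM in this assay, with a range from 25000 nM to 150000 nM.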

Compound 3, concentration lethal to 50% of the cells: < 100000 nM
Compound 3 ended at the assay's limit; the forecaster's own chance of this, stated with the estimate: 40%; the middle value is on the limit's open side.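

No step can be read from compound 2 to compound 3, because both compounds stop at an assay limit: the limit of < 100000 nM in this assay, at which 2 of the 3 values shown sit. The compounds shown leave open whether fluoro in place of methoxy on an aromatic carbon shifts the value in this assay at all, and by how much.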